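A few compounds are considered here, and "the series" means these few. Any claim that something is new, unique, unknown or untested is made for them only; others in the source may bear on it.

Measured so far:
- compound 1 `CN(c1nc2ccc(NC(=O)CCc3ccc(C(F)(F)F)cc3)cc2[nH]1)C1CC1` — 24 nM
- compound 2 `CC(C)N(C)c1ccc2nc(NC(=O)CCc3ccc(C(F)(F)F)cc3)ccc2n1` — 375 nM

Both numbers come from an assay on CHO-K1 cells for displacement of a labelled ligand from melanin-concentrating hormone receptor 1 (Homo sapiens), read by scintillation counting; on this read-out lower numbers stand for stronger inhibition and higher numbers for weaker inhibition. Compound 1 gives 24 nM and stands lowest of the two. Compound 2 gives 375 nM, a gap well beyond the scatter, but the two differ in more than one place, so no single change can be read from the pair.

Compound 3 `CN(C)c1nc2ccc(NC(=O)CCc3ccc(C(F)(F)F)cc3)cc2[nH]1` is the next step from compound 1: methyl in place of cyclopropyl on a nitrogen on an aromatic ring. Among the measured compounds shown here, no measured pair tells what this exchange does in this assay. The change is small and removes only the three-membered ring, so a small weakening at most is expected, quite possibly none beyond the scatter.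

The estimate is accordingly a step of a 1.7-fold higher number from compound 1 to compound 3 (0.22 log units; within the scatter) from compound 1 to compound 3, and compound 3 is expected at 40 nM in this assay, with a range from 12 nM to 130 nM.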

Compound 3, half-maximal inhibitory concentration: 12 nM
The estimate for compound 3 lay 3.3-fold (0.52 log units) above the measured number; the measured number falls inside the stated range.
By their numbers in this assay, from the lowest: compounds 3 and 1 (each within the scatter of the next); then compound 2.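

In this assay, among the compounds shown here, methyl in place of cyclopropyl on a nitrogen on an aromatic ring gives a 2.0-fold lower number from compound 1 to compound 3 (0.30 log units; within the scatter), the first reading of a single change at this position. The three-membered ring is therefore not required on this nitrogen for a number in the range of compound 1, and the cyclopropyl(methyl)amino to dimethylamino exchange cannot be told from the scatter. Nothing at hand explains why these two groups read alike.

Still open, from the compounds shown here alone, is how much room this nitrogen allows, since a cyclobutyl group, a longer chain or a ring amine such as morpholine in place of the dimethylamino group could read quite differently. Also open, going by these compounds, is whether any carbon group is needed here at all, as a plain amine on the shared core would show.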